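A few compounds are considered here, and "the series" means these few. Any claim that something is new, unique, unknown or untested is made for them only; others in the source may bear on it.

Compound 3 `O=C(O)Cc1ccc2ccc(C(=O)c3ccc(C(F)(F)F)cc3)c-2cc1` stands highest of the three compounds in an assay on cells for displacement of a labelled ligand from Orexin receptor type 2 (Homo sapiens), read by scintillation counting, with stated times of 10 min and 90 min, tested at 10 uM (a higher number here means more inhibition at the concentration tested (going by the name of the read-out), a lower number less inhibition), where compound 3 gives 11.2%. Compound 1 `O=C(O)c1ccc2ccc(C(=O)c3ccc(C(F)(F)F)cc3)c-2cc1` gives 1% and compound 2 `COC(=O)Cc1ccc2ccc(C(=O)c3ccc(C(F)(F)F)cc3)c-2cc1` gives 1% in this assay. The steps run a number 10.2 percentage points higher from compound 1 to compound 3 (beyond the scatter) and a number 10.2 percentage points higher from compound 2 to compound 3 (beyond the scatter), while no change at the digits printed from compound 1 to compound 2 (within the scatter). Compound 4 `Cc1ccc2ccc(C(=O)c3ccc(C(F)(F)F)cc3)c-2cc1` differs from compound 3 in one place: hydrogen in place of carboxy on a saturated chain carbon bound to an aromatic carbon. The two steps that bear on it, from compound 1 and from compound 2 to compound 3, were both modest gains on arrival of the carboxymethyl group; removal of the carboxy from compound 3 is expected to give a modest drop, a number 8.2 percentage points lower from compound 3 to compound 4 (within the scatter), in this assay. Compound 4 is therefore estimated at 3%, within 0% to 12%.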

Compound 4, a percentage reported as inhibition, at one concentration (the size of the read-out at that concentration, not a potency): 31%
Estimate against measurement, compound 4: 28 percentage points below; measured number above the stated range.
By their numbers in this assay, from the lowest: compounds 1 and 2 (each within the scatter of the next); then compound 3; then compound 4.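

In this assay, the carboxy and the ester are both worse here than plain methyl: removing carboxy from the saturated chain carbon gives a number 19.8 percentage points higher from compound 3 to compound 4 (beyond the scatter), removing methoxycarbonyl there gives a number 30 percentage points higher from compound 2 to compound 4 (beyond the scatter), and methyl in place of carboxy on the aromatic carbon gives a number 30 percentage points higher from compound 1 to compound 4 (beyond the scatter). The gain seen on arrival of carboxymethyl therefore does not credit the carboxy itself, as compound 4, with neither acid nor ester, stands highest of the four. No measurement on hand accounts for this.

As far as these compounds go, whether methyl itself adds anything remains open. So does how an amine, a hydroxymethyl group or a longer alkyl chain at this place would read.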